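The source may report more compounds than this note shows. Statements on the series, on what has been measured and on what is new or still open speak of the compounds shown alone.

Compound 1 `COc1ccc(Cl)cc1C(=O)Nc1ccc(C2=NN(c3ccccc3)C(c3ccccc3[N+](=O)[O-])C2)cc1` gives 80.2% in a functional assay on the whole organism (strain albino) with Rattus norvegicus as the target, read by paw edema, with stated times of 1 h and 4 h, at a dose of 25 mg/kg by the oral route; on this read-out higher numbers stand for a stronger effect at the one dose given and lower numbers for a weaker effect. Compound 2 `COc1ccc(Cl)cc1C(=O)Nc1ccc(C2=NN(c3ccccc3)C(c3ccc([N+](=O)[O-])cc3)C2)cc1` gives 90.9% in this assay; the change 4-nitrophenyl in place of 2-nitrophenyl on a saturated ring carbon carries a number 10.7 percentage points higher from compound 1 to compound 2 (beyond the scatter). Compound 3 `COc1ccc(Cl)cc1C(=O)Nc1ccc(C2=NNC(c3ccccc3[N+](=O)[O-])C2)cc1` gives 88.3% in this assay; it differs from compound 1 by hydrogen in place of phenyl on an amine nitrogen in a ring, a step of a number 8.1 percentage points higher from compound 1 to compound 3 (within the scatter). Compound 4 `COc1ccc(Cl)cc1C(=O)Nc1ccc(C2=NNC(c3ccc([N+](=O)[O-])cc3)C2)cc1` is unmeasured; from compound 3 it is reached by 4-nitrophenyl in place of 2-nitrophenyl on a saturated ring carbon, the same kind of change as that from compound 1 to compound 2, though around the place the earlier one sits next to the ring atom that bears a phenyl group (6 heavy atoms), which compound 3 and compound 4 lack. Beside the earlier step, a smaller step of a number 4.7 percentage points higher from compound 3 to compound 4 (within the scatter) is expected here, because compound 3 already gives 88.3% and the scale of this read-out leaves little room above it. Compound 4 is estimated at 93%, expected to fall between 85% and 99%.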

Compound 4, a percentage reported as activity, at one dose (the size of the read-out at that dose, not a potency): 91.3%
Estimate against measurement, compound 4: 1.7 percentage points above, and the stated range covers the measured number.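

In this assay, 4-nitrophenyl in place of 2-nitrophenyl on a saturated ring carbon gives a number 3 percentage points higher from compound 3 to compound 4 (within the scatter), and the two readings of this change do not differ beyond the scatter: the same change on two cores in this assay, a number 10.7 percentage points higher (beyond the scatter) from compound 1 to compound 2 and a number 3 percentage points higher (within the scatter) from compound 3 to compound 4, 7.7 percentage points apart, within the scatter of two such steps

Hydrogen in place of phenyl on an amine nitrogen in a ring gives a number 0.4 percentage points higher from compound 2 to compound 4 (within the scatter), and this change also reads alike on both cores: the same change on two cores in this assay, a number 8.1 percentage points higher (within the scatter) from compound 1 to compound 3 and a number 0.4 percentage points higher (within the scatter) from compound 2 to compound 4, 7.7 percentage points apart, within the scatter of two such steps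

Within the data shown here, this agreement does not show that either step has a fixed size: each change rests on only two pairs, and only the step from compound 1 to compound 2 lies beyond the scatter.

Open, as far as these compounds go, is how an amine or a carboxylic acid in place of the nitro group would read on either core. Also open, from the compounds shown here alone, is how an acetyl group would read on the ring nitrogen.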